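The source may report more compounds than this note shows. Statements on the series, on what has been measured and on what is new or still open speak of the compounds shown alone.

Of the compounds shown here, three sharing one core have been measured in a functional assay on SN12C cells (Homo sapiens) for inhibition, read by sulforhodamine B assay, with a stated time of 48 h, tested at 10 uM; on this read-out lower numbers stand for less inhibition and higher numbers for more inhibition at the one concentration tested (going by the name of the read-out). Compound 1 `COc1ccc(-c2cn3ccnc3c(-c3ccc4ncn(C5CCCCC5)c4c3)n2)cc1` gives 63.6% in this assay. Compound 2 `Clc1ccc(-c2cn3ccnc3c(-c3ccc4ncn(C5CCCCC5)c4c3)n2)cc1` gives 13.5%, and compound 3 `Brc1ccc(-c2cn3ccnc3c(-c3ccc4ncn(C5CCCCC5)c4c3)n2)cc1` gives 18.4%. Compound 3 therefore sits second among the three numbers, close to compound 2 and far from compound 1. The swap of a methoxy for a halogen cost a great deal: a number 50.1 percentage points lower from compound 1 to compound 2 (beyond the scatter) and a number 45.2 percentage points lower from compound 1 to compound 3 (beyond the scatter). Exchanging one halogen for another changed little: a number 4.9 percentage points higher from compound 2 to compound 3 (within the scatter).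

Compound 4 `FC(F)(F)c1cccc(-c2cn3ccnc3c(-c3ccc4ncn(C5CCCCC5)c4c3)n2)c1` is the next step, and its change from compound 3 is 3-(trifluoromethyl)phenyl in place of 4-bromophenyl on an aromatic carbon. Within the data shown here, no measured step replaces a halogen with a trifluoromethyl, nor moves a group from one position on the phenyl ring to another, so the two halogen-bearing compounds are the only guide. Among the measured compounds shown here, both halogen compounds, compound 2 and compound 3, are low, and the one halogen-to-halogen step stayed within the scatter. Compound 4 is therefore expected to stay near the low end, with a number 3.6 percentage points higher from compound 3 to compound 4 (within the scatter) as the estimated step. The estimate for compound 4 in this assay is 22%, within a range from 5% to 48%.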

Compound 4, a percentage reported as inhibition, at one concentration (the size of the read-out at that concentration, not a potency): 8.3%
The estimate for compound 4 lay 13.7 percentage points above the measured number; the range from low to high includes it.
By their numbers in this assay, from the lowest: compounds 4, 2 and 3 (each within the scatter of the next, the first and the last beyond it); then compound 1.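

In this assay, the new 3-(trifluoromethyl)phenyl group gives a number 10.1 percentage points lower from compound 3 to compound 4 (beyond the scatter), a real if small step, while a number 5.2 percentage points lower from compound 2 to compound 4 (within the scatter), so compound 2 and compound 4 cannot be told apart. The larger contrast is with the methoxy compound, a number 55.3 percentage points lower from compound 1 to compound 4 (beyond the scatter), so a phenyl ring carrying neither chloro nor bromo also reads far from compound 1, and among these four compounds, 4-methoxyphenyl is the only group at this position that gives a high number. Nothing available here explains why these groups differ in this way.

This step changes both the group on the phenyl ring and where it sits, so it cannot show how much of the difference comes from trifluoromethyl and how much from its place on the ring. It also leaves open whether the high number of compound 1 depends on the methoxy group itself, a question that a plain phenyl ring, or one carrying a hydroxyl, an ethoxy or an amine, could help to answer.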